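Ethyl for Cyclobutyl on the Piperazine of Compound 3

The compounds below may be only part of what the source reports. "The series", "measured", "known", "first", "only" and "open" are said of these compounds alone.

Of the compounds shown here, three have been measured in a functional assay on CHO-K1 cells for antagonist activity at Urotensin-2 receptor (Rattus norvegicus), read by FLIPR and calcium flux, with a stated time of 1 h; a lower number here means a stronger inhibitor, a higher number a weaker inhibitor. Compound 1 `CCN1CCN(c2cccc3c2C(=O)N([C@H](CCCNS(=O)(=O)c2cn(C)c(C)n2)c2ccc(OC)c(OC)c2)C3=O)CC1` gives 140 nM in this assay, and compound 2 `CCN1CCN(c2cccc3c2CN([C@H](CCCNS(=O)(=O)c2c[nH]cn2)c2ccc(OC)c(OC)c2)C3=O)CC1` gives 23 nM. Compound 3 `COc1ccc([C@@H](CCCN(C)S(=O)(=O)c2cccs2)N2Cc3c(cccc3N3CCN(C4CCC4)CC3)C2=O)cc1OC` gives 4 nM in this assay, the lowest of the three numbers; its gap to compound 2 and its wider gap to compound 1 both lie beyond the scatter, so compound 3 stands as the strongest inhibitor of this set. For the measured compounds named here, no two measured compounds differ in a single place, so none of these gaps can be tied to one change.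

Compound 4 `CCN1CCN(c2cccc3c2CN([C@H](CCCN(C)S(=O)(=O)c2cccs2)c2ccc(OC)c(OC)c2)C3=O)CC1` differs from compound 3 in one place: ethyl in place of cyclobutyl on an amine nitrogen in a ring. Compound 2 carries the same ethyl piperazine together with a different sulfonamide part and gives 23 nM in this assay, while compound 1, also with the ethyl group but with a different core, gives 140 nM; neither offers a clean comparison for this change. The change is therefore expected to read a 2.0-fold higher number from compound 3 to compound 4 (0.30 log units; within the scatter), a modest step toward a weaker inhibitor, near the edge of the scatter. Compound 4 is estimated to give 8 nM in this assay, with a range from 2.5 nM to 25 nM.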

Compound 4, half-maximal inhibitory concentration: 7 nM
For compound 4 the middle estimate is 1.1-fold (0.06 log units) above the measured one; the measured number falls inside the stated range.
By their numbers in this assay, from the lowest: compounds 3 and 4 (each within the scatter of the next); then compound 2; then compound 1.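

Replacing the cyclobutyl on this ring nitrogen with ethyl leaves the reading in this assay essentially unresolved (a 1.8-fold higher number from compound 3 to compound 4 (0.24 log units; within the scatter)), so the two groups cannot be told apart here, and a low number at this position does not depend on the four-membered ring of carbon. For the compounds shown here, compound 4 also gives the first comparison in which the 4-ethylpiperazin-1-yl group is held constant and only the sulfonamide part changes: methyl((thiophen-2-yl)sulfonyl)amino in place of ((1H-imidazol-4-yl)sulfonyl)amino gives a modest step beyond the scatter (a 3.3-fold lower number from compound 2 to compound 4 (0.52 log units; beyond the scatter)), which ties part of the earlier gap to that one place. No measured evidence accounts for either step.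

With only ethyl and cyclobutyl shown on this nitrogen, it remains open how a methyl, an isopropyl, a cyclohexyl or a plain hydrogen there would read. On these data alone, in the sulfonamide step the thiophene and the methyl on the sulfonamide nitrogen enter together, so their separate contributions remain unknown, and the core of compound 1 still has no one-place comparison.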